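The source may report more compounds than this note shows. Statements on the series, on what has been measured and on what is new or still open speak of the compounds shown alone.

Measured so far in a functional assay on HL-60 cells (Homo sapiens) for inhibition, read by MTT assay, with a stated time of 72 h; a lower number here means a stronger inhibitor, a higher number a weaker inhibitor:
- compound 1 `CCc1nc(-c2ccc(F)cc2)c(C(=O)N2CCN(c3cccc(Cl)c3)CC2)o1`: 169 nM
- compound 2 `CCc1nc(-c2cccc(F)c2)c(C(=O)N2CCN(c3cccc(Cl)c3)CC2)o1`: 317 nM

Compound 2, at 317 nM, lies within the scatter of compound 1, so these two values give no order. Among the compounds with values here, the only measured step is a 1.9-fold higher number from compound 1 to compound 2 (0.27 log units; within the scatter). It is 3-fluorophenyl in place of 4-fluorophenyl, at the same place on the shared core.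

The next compound is compound 3 `CCc1nc(-c2ccc(OC)c(OC)c2)c(C(=O)N2CCN(c3cccc(Cl)c3)CC2)o1`, which differs from compound 2 as follows: 3,4-dimethoxyphenyl in place of 3-fluorophenyl on an aromatic carbon. Here 3,4-dimethoxyphenyl replaces 3-fluorophenyl on the same aromatic carbon. The measured step bears on this change only in part, since it touches the same aryl group but involves no methoxy group. Within the data shown here, no measured compound carries one, so the size of this change is not known from the data.

Among the measured compounds shown here, with a 1.9-fold higher number from compound 1 to compound 2 (0.27 log units; within the scatter) as the sole guide, no step beyond the scatter is expected in this assay, though with wide uncertainty in either direction. The estimated change is a 1.0-fold higher number from compound 2 to compound 3 (0.00 log units; within the scatter). For compound 3 the expected value is 320 nM, with an estimated range of 110 nM to 900 nM.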

Compound 3, half-maximal inhibitory concentration: "not active" (no number reported)
The entry for compound 3 holds no number; there is nothing to compare the estimate with.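

Within the data shown here, compound 3 is recorded as "not active" with no number in this assay, so no step from compound 2 to compound 3 can be read. No measurement shown accounts for this entry. The compounds shown leave open how large the change from 3-fluorophenyl to 3,4-dimethoxyphenyl is in this assay.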